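From Bromo to Ethoxy: Estimating Compound 4

This account rests on a few compounds, and the source may have more. Where it says the series, first, only, none or still open, it means among the compounds named here.

Of the compounds shown here, three sharing one core have been measured in an in vitro assay on cells for inhibition of Amine oxidase [flavin-containing] B (Homo sapiens), read by fluorescence and spectrophotometry, with a stated time of 20 min; a lower number here means a stronger inhibitor, a higher number a weaker inhibitor. Compound 1 `Cn1c(=O)c2c(nc(CSc3cccc(F)c3)n2C)n(C)c1=O` gives 22300 nM. Compound 2 `COc1cccc(SCc2nc3c(c(=O)n(C)c(=O)n3C)n2C)c1` gives 8420 nM, and compound 3 `Cn1c(=O)c2c(nc(CSc3cccc(Br)c3)n2C)n(C)c1=O` gives 4900 nM. Among the three, compound 3 shows the lowest number, with a 4.6-fold lower number from compound 1 to compound 3 (0.66 log units; beyond the scatter) and a 1.7-fold lower number from compound 2 to compound 3 (0.24 log units; within the scatter), so it stands apart from compound 1 but not from compound 2. The step of a 2.6-fold lower number from compound 1 to compound 2 (0.42 log units; beyond the scatter) likewise separates compound 2 from compound 1.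

Compound 4 `CCOc1cccc(SCc2nc3c(c(=O)n(C)c(=O)n3C)n2C)c1` carries ethoxy in place of bromo on an aromatic carbon. Within the data shown here, no measured pair compares ethoxy with any other group, so the nearest guide is the step of a 1.7-fold lower number from compound 2 to compound 3 (0.24 log units; within the scatter), which concerns methoxy rather than ethoxy and runs in the opposite direction. Read backwards, that step suggests an alkoxy group on that aromatic carbon gives a number close to, or somewhat above, that of bromo. Compound 4 is therefore expected to show a 1.4-fold higher number from compound 3 to compound 4 (0.15 log units; within the scatter) in this assay, a change that may not exceed the scatter. The estimate for compound 4 is 7000 nM, with a range from 2500 nM to 20000 nM, the upper part of that range resting on compound 2 because it gives 8420 nM.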

Compound 4, half-maximal inhibitory concentration: 18400 nM
Beside the measured number, compound 4's estimate is 2.6-fold (0.42 log units) below it; the measured number falls inside the stated range.
By their numbers in this assay, from the lowest: compounds 3 and 2 (each within the scatter of the next); then compounds 4 and 1 (each within the scatter of the next).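

In this assay, among these compounds, the alkoxy chain at this aromatic carbon turns out to matter, since lengthening methoxy to ethoxy gives a 2.2-fold higher number from compound 2 to compound 4 (0.34 log units; beyond the scatter) and so separates two groups that the earlier compounds could not compare. Bromo and methoxy had stayed within the scatter of each other, but ethoxy in place of bromo gives a 3.8-fold higher number from compound 3 to compound 4 (0.57 log units; beyond the scatter) and so the two alkoxy groups do not stand in the same relation to bromo. Ethoxy in place of fluoro gives a 1.2-fold lower number from compound 1 to compound 4 (0.08 log units; within the scatter) and this places ethoxy level with fluoro, so among these four compounds the bromo and methoxy compounds form one level and the fluoro and ethoxy compounds another, with no order by the size of the group entering at this position.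

The data shown offer no measurement that accounts for the difference between methoxy and ethoxy at this position. From the compounds shown here alone, it remains open whether a longer chain such as propoxy would carry the number further up, and whether chloro, an amine or a carboxylic acid on the same aromatic carbon would fall with bromo or with ethoxy.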